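Amide nitrogen substituent removal in the tricyclic series

This account rests on a few compounds, and the source may have more. Where it says the series, first, only, none or still open, it means among the compounds named here.

Three analogues carry the same core; compound 1 `CCC1C(=O)N(C)c2cnc(Nc3ccc(S(=O)(=O)NCCO)cc3)nc2N1c1ccn(C)n1` bears an arylamino group at the core and is reported in a functional assay on HeLa cells (Homo sapiens) for antiproliferative activity, read by CCK-8 assay, with a stated time of 72 h (a lower number here means a stronger inhibitor of growth, a higher number a weaker inhibitor of growth), as "not active" (no number reported). Compound 2 `CCC1C(=O)N(C)c2cnc(-n3ccc4cc(C(=O)NC(C)C)ccc43)nc2N1c1ccn(C)n1` gives 4350 nM in this assay, while compound 3 `CC[C@@H]1C(=O)N(C)c2cnc(-n3ccc4cc(C(=O)NCC(C)C)ccc43)nc2N1C1CCCC1` gives 3280 nM. Compound 3 holds the lowest of the two reported numbers, but its gap to compound 2 lies within the scatter, so no order between the two can be claimed. Compound 4 `CC[C@@H]1C(=O)N(C)c2cnc(-n3ccc4cc(C(N)=O)ccc43)nc2N1C1CCCC1` differs from compound 3 by hydrogen in place of isobutyl on an amide-type nitrogen. Among the measured compounds shown here, no step between measured compounds exists for this change, so the expectation rests on compound 3 alone. Compound 4 is expected to give 5500 nM in this assay, between 2200 nM and 14000 nM, a step of a 1.7-fold higher number from compound 3 to compound 4 (0.22 log units; within the scatter) toward a somewhat higher number, at the edge of the scatter.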

Compound 4, concentration for 50% growth inhibition: 674 nM
The estimate for compound 4 lay 8.2-fold (0.91 log units) above the measured number; the whole stated range lies above it.
By their numbers in this assay, from the lowest: compound 4; then compounds 3 and 2 (each within the scatter of the next).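

Among the compounds shown here, replacing isobutyl with hydrogen on the amide-type nitrogen gives a 4.9-fold lower number from compound 3 to compound 4 (0.69 log units; beyond the scatter) in this assay and is the first change to exceed the scatter. The isobutyl is therefore not required for growth inhibition in this pair, and the plain carbamoyl gives the lower number. Nothing on hand explains this step.

From the compounds shown here alone, whether a methyl or ethyl group on this nitrogen keeps the lower number remains open. Going by these compounds, the step also rests on one pair, so its transfer to the ring substitution of compound 2 is unknown.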